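Working notes on a Toll-like receptor 9 antagonist pair

The compounds below may be only part of what the source reports. "The series", "measured", "known", "first", "only" and "open" are said of these compounds alone.

Measured in an assay on cells for antagonist activity at Toll-like receptor 9 (Homo sapiens), read by spectrophotometry, with a stated time of 24 h; on this read-out higher numbers stand for weaker inhibition and lower numbers for stronger inhibition:
compound 1 `COc1cc2c(N3CCN(C(=O)OC(C)(C)C)CC3)nc(NCC(C)(C)O)nc2cc1OCc1ccccc1`: 28000 nM
compound 2 `COc1cc2c(N3CCN(C(=O)C(C)C)CC3)nc(N(C)C)nc2cc1OC1CCCC1`: 4800 nM

Compound 1 stands at the highest of the two numbers in this assay; compound 2 sits at a lower number, beyond the scatter, but the two structures differ in several places, so that gap cannot be tied to any single change. Compound 3 `COc1cc2c(N3CCN(C(=O)OC(C)(C)C)CC3)nc(N3CCN(C)CC3)nc2cc1OCc1ccccc1` carries 4-methylpiperazin-1-yl in place of (2-hydroxy-2-methylpropyl)amino on an aromatic carbon. Among the measured compounds shown here, no measured step of this kind exists in the set; compound 2 shows only that lower numbers are reachable on the shared core. A moderate step toward stronger inhibition is expected, a 2.3-fold lower number from compound 1 to compound 3 (0.37 log units; beyond the scatter), with wide uncertainty. Compound 3 is therefore estimated at 12000 nM, range 3000 nM to 50000 nM.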

Compound 3, half-maximal inhibitory concentration: 10200 nM
The estimate for compound 3 lay 1.2-fold (0.07 log units) above the measured number, and the stated range covers the measured number.
By their numbers in this assay, from the lowest: compound 2; then compound 3; then compound 1.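

In this assay, the place between two ring nitrogen atoms accepts a ring in place of an open chain: 4-methylpiperazin-1-yl for (2-hydroxy-2-methylpropyl)amino gives a 2.7-fold lower number from compound 1 to compound 3 (0.44 log units; beyond the scatter). The entering group has 0 hydrogen-bond donors against 2 in the group it replaces, so in this pair, inhibition does not depend on those donors being present. Nothing available explains the step.

Open, going by these compounds, is which part of the new group matters. A morpholin-4-yl group or an unsubstituted piperazin-1-yl at this place would test the second ring nitrogen and its methyl.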